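From Methoxy to Bromo on the Fused Ring

The source may report more compounds than this note shows. Statements on the series, on what has been measured and on what is new or still open speak of the compounds shown alone.

Three compounds have been measured in a functional assay on A549 cells (Homo sapiens) for inhibition, tested at 0.1 uM; a higher number here means a stronger effect of the compound at the concentration tested, a lower number a weaker effect:

Compound 1, `COc1ccc2c(c1)c(-c1cc(C(F)(F)F)c(C#N)c(-c3cn(S(=O)(=O)c4ccc(C)cc4)c4ccc(OC)cc34)n1)cn2S(=O)(=O)c1ccc(C)cc1`, gives 25%.
Compound 2, `COc1ccc2c(c1)c(-c1cc(C(F)(F)F)ccn1)cn2S(=O)(=O)c1ccc(C)cc1`, gives 16.9%.
Compound 3, `Cc1ccc(S(=O)(=O)n2cc(-c3cc(C(F)(F)F)cc(-c4cn(S(=O)(=O)c5ccc(C)cc5)c5ccccc45)n3)c3ccccc32)cc1`, gives 37.5%.

Compound 2 shows the lowest of the three numbers. The nearest is compound 1, whose reading lies higher by an amount that falls within the usual scatter of this assay, so the two cannot be told apart. The furthest is compound 3, whose reading lies higher by an amount beyond the scatter.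

Compound 4, `Cc1ccc(S(=O)(=O)n2cc(-c3cc(C(F)(F)F)ccn3)c3cc(Br)ccc32)cc1`, has not yet been measured. It differs from compound 2 in one place: bromo in place of methoxy on an aromatic carbon. Among the measured compounds shown here, no measured pair in this set shows the same exchange, so there is no step to lean on. With only the numbers of compound 2 to go by, the change is expected to move the reading little, in either direction, and no step beyond the scatter is anticipated in this assay. The step from compound 2 to compound 4 is therefore estimated as a number 3.1 percentage points higher from compound 2 to compound 4 (within the scatter). Compound 4 is expected to give about 20%, within a range from 5% to 38%.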

Compound 4, a percentage reported as inhibition, at one concentration (the size of the read-out at that concentration, not a potency): 38.9%
Compound 4: middle estimate off by 18.9 percentage points, on the low side, and the stated range ends below it.
By their numbers in this assay, from the lowest: compounds 2 and 1 (each within the scatter of the next); then compounds 3 and 4 (each within the scatter of the next).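

In this assay, among the compounds shown here, the aromatic carbon that carries methoxy in compound 2 proves sensitive to what sits on it: bromo in place of methoxy gives a number 22 percentage points higher from compound 2 to compound 4 (beyond the scatter), and this modest step is the only reading so far of a change in one place. The earlier compounds shown here differ from one another in several places at once, so they could say nothing about this position on its own; now one position on the fused ring system is tied to a change in the reading, measured at a single concentration and not as a potency. The data hold nothing that accounts for the step.

A single exchange cannot separate what losing methoxy contributes from what gaining bromo contributes, and an amine or a carboxylic acid on the same aromatic carbon would show whether other groups move the reading as well. From the compounds shown here alone, it also stays open whether bromo in place of methoxy would give a similar step on a larger compound such as compound 1, which also carries methoxy.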